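Solubility notes: cyano for ethyl on the pendant phenyl

The source may hold more compounds than are shown below. What is called first, only, known or untested is meant among the compounds shown, and "the series" means these compounds.

Measured compounds:
compound 1 `CCc1ccc(-c2nc3c(c(C)nn3-c3ccccc3)c(-c3ccccc3O)c2C#N)cc1` — 3100 nM
compound 2 `CCc1ccc(-c2nc3c(c(C)nn3-c3ccccc3)c(-c3ccccc3Cl)c2C#N)cc1` — 1700 nM
compound 3 `CCc1ccc(-c2nc3c(c(C)nn3-c3ccccc3)c(-c3cccc(O)c3)c2C#N)cc1` — 18000 nM

In a physicochemical assay for solubility, read by spectrophotometry, in phosphate buffer, with a stated time of 18 h, at pH 7.4 (a lower number here means a less soluble compound, a higher number a more soluble compound), compound 1 stands second highest of the three numbers. Its nearest neighbour is compound 2: a 1.8-fold lower number from compound 1 to compound 2 (0.26 log units; within the scatter). The furthest is compound 3: a 5.8-fold higher number from compound 1 to compound 3 (0.76 log units; beyond the scatter). The remaining measured pair runs the same way: an 11-fold higher number from compound 2 to compound 3 (1.02 log units; beyond the scatter).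

Compound 4 `Cc1nn(-c2ccccc2)c2nc(-c3ccc(C#N)cc3)c(C#N)c(-c3ccccc3O)c12` is not yet measured. Against compound 1 the difference is cyano in place of ethyl on an aromatic carbon. Every measured step changes the other aryl ring, the one bearing hydroxy or chloro, so none bears directly on this exchange of cyano for ethyl; the two larger steps involve the hydroxy position and give no guide here. With nothing comparable in the set, the expectation is a step within the scatter, direction uncertain: a 1.3-fold higher number from compound 1 to compound 4 (0.11 log units; within the scatter) is the estimated step from compound 1 to compound 4. Compound 4 is therefore expected to give about 4000 nM in this assay, within a range of 1500 nM to 11000 nM.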

Compound 4, solubility: 1700 nM
The estimate for compound 4 lay 2.4-fold (0.37 log units) above the measured number; measured number inside the range.
By their numbers in this assay, from the lowest: compounds 2, 4 and 1 (each within the scatter of the next); then compound 3.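

Among the compounds shown here, compound 4 gives the first reading at the para position of the pendant phenyl: in this assay, cyano in place of ethyl there gives a step within the scatter (a 1.8-fold lower number from compound 1 to compound 4 (0.26 log units; within the scatter)). For the compounds shown here, this exchange therefore does not separate compound 4 from compound 1, whereas moving the hydroxy group on the other aryl ring gives a step beyond the scatter (a 5.8-fold higher number from compound 1 to compound 3 (0.76 log units; beyond the scatter)), so the one change read at this position has a smaller effect on the number than that move. No measurement shown bears on why the exchange gives this result.

Open, from the compounds shown here alone, is whether a carboxylic acid or an amine on this carbon would give a step beyond the scatter. Also open, going by these compounds, is whether cyano in place of ethyl reads the same with the 3-hydroxyphenyl of compound 3 in place.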